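Swapping the Methoxy Amide for a Tetrazolylethyl Amide

The source may hold more compounds than are shown below. What is called first, only, known or untested is meant among the compounds shown, and "the series" means these compounds.

Compound 1 `NCc1cc(O[C@@H]2CCCN(C(=O)Nc3ccccc3)C2)nc(C(F)(F)F)c1`: "not determined" (no result reported)
Compound 2 `NCc1cc(Oc2cccc(Oc3ccccc3)c2)nc(C(F)(F)F)c1`: "not determined" (no result reported)
Compound 3 `CONC(=O)c1cccc(Oc2cc(CN)cc(C(F)(F)F)n2)c1`: 8780 nM

Within the data shown here, compounds 1 and 2 have no number in an ADME assay on the whole organism (lung, Mus musculus) for pharmacokinetics, read by LC-MS, at a dose of 30 mg/kg by the oral route (on this read-out higher numbers stand for higher exposure at the dose given and lower numbers for lower exposure), so compound 3 stands alone with the only value shown, 8780 nM in this assay.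

Compound 4 `NCc1cc(Oc2cccc(C(=O)NCCn3cnnn3)c2)nc(C(F)(F)F)c1` differs from compound 3 in one place: 2-(1H-tetrazol-1-yl)ethyl in place of methoxy on an amide-type nitrogen. Among the measured compounds shown here, no step between two measured compounds exists to guide the size of this change, so the expectation rests on compound 3 alone.

With a larger group entering, the maximal plasma concentration of compound 4 is expected to sit somewhat lower, a step of a 1.8-fold lower number from compound 3 to compound 4 (0.24 log units; within the scatter), though it may remain within the usual scatter. Compound 4 is estimated at 5000 nM, between 1500 nM and 15000 nM.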

Compound 4, maximal plasma concentration: 3460 nM
For compound 4 the middle estimate is 1.4-fold (0.16 log units) above the measured one; the measured number falls inside the stated range.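

Putting 2-(1H-tetrazol-1-yl)ethyl in place of methoxy on the amide-type nitrogen gives, in this assay, a 2.5-fold lower number from compound 3 to compound 4 (0.40 log units; beyond the scatter). This shows that the group on this nitrogen does bear on the read-out, though only modestly, and that a much larger group with a five-membered aromatic ring still leaves a clear measured value. No measurement here explains the step.

Going by these compounds, whether the chain or the tetrazole ring matters more stays open. A plain ethyl group, a longer alkyl chain or a carboxylic acid on the same nitrogen could help separate the two.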